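Hydroxyethyl in Place of Ethynyl on the Ester Chain

The source may hold more compounds than are shown below. What is called first, only, known or untested is meant among the compounds shown, and "the series" means these compounds.

Among the measured compounds shown here, compound 2 `C#CC(C)OC(=O)c1ccc(C(CC)(CC)c2ccc(OCC(=O)C(C)(C)C)c(C)c2)n1CC` stands at the lowest of the two numbers measured so far: in an assay on HL-60 cells for agonist activity at vitamin D3 receptor (Homo sapiens), read by microscopy, with a stated time of 96 h (on this read-out lower numbers stand for an effect already at smaller amounts and higher numbers for an effect only at larger amounts of compound), compound 2 gives 210 nM, while compound 1 `CCn1c(C(=O)N(C)CCC#N)ccc1C(CC)(CC)c1ccc(OCC(=O)C(C)(C)C)c(C)c1` gives 9800 nM. For the measured compounds named here, the single measured step, a 47-fold lower number from compound 1 to compound 2 (1.67 log units; beyond the scatter), concerns the group on the carbonyl carbon and not the chain altered here. Compound 3 `CCn1c(C(=O)OC(C)CCO)ccc1C(CC)(CC)c1ccc(OCC(=O)C(C)(C)C)c(C)c1` differs from compound 2 by 2-hydroxyethyl in place of ethynyl on a saturated chain carbon bound to an oxygen next to a carbonyl group and a saturated chain carbon. Going by the values given here, no measured step bears directly on this change, so for compound 3 only a modest rise is expected, a 2.4-fold higher number from compound 2 to compound 3 (0.38 log units; beyond the scatter). Compound 3 is estimated at 500 nM, within a range from 120 nM to 2500 nM.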

Compound 3, half-maximal effective concentration: 380 nM
Compound 3: middle estimate off by 1.3-fold (0.12 log units), on the high side; the range from low to high includes it.
By their numbers in this assay, from the lowest: compounds 2 and 3 (each within the scatter of the next); then compound 1.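

In this assay the change to 2-hydroxyethyl gives a 1.8-fold higher number from compound 2 to compound 3 (0.26 log units; within the scatter) and so leaves the number within the scatter: at this place on the chain, the triple bond of ethynyl is not needed to hold it. The ester-linked 3-hydroxy-1-methylpropyl group also keeps a 26-fold lower number from compound 1 to compound 3 (1.41 log units; beyond the scatter), so a second group on the carbonyl carbon reads far from the (2-cyanoethyl)(methyl)amino group of compound 1. Nothing available explains why compound 2 and compound 3 read alike. Still open, from the compounds shown here alone, is whether an amine or a carboxylic acid in place of the hydroxyl would hold this number. Going by these compounds, a longer chain at the same place remains equally open.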